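The source may hold more compounds than are shown below. What is called first, only, known or untested is meant among the compounds shown, and "the series" means these compounds.

Measured compounds:
- compound 1 `COc1cc(-c2cc(/C=C/C(=O)c3ccc(N)cc3)[nH]n2)cc(OC)c1OC` — 1100 nM
- compound 2 `COc1cc(-c2cc(/C=C/C(=O)c3ccc(Cl)c(Cl)c3)[nH]n2)cc(OC)c1OC` — 2950 nM

In a functional assay on HCT-116 cells (Homo sapiens) for inhibition, read by sulforhodamine B assay, with a stated time of 48 h (on this read-out lower numbers stand for stronger inhibition of growth and higher numbers for weaker inhibition of growth), compound 1 gives 1100 nM. Among the compounds with values here, compound 2, which carries a 3,4-dichlorophenyl on the carbonyl carbon, gives 2950 nM in this assay; of the two numbers measured so far it is the higher one, its only neighbour being compound 1, which is reached by a 2.7-fold higher number from compound 1 to compound 2 (0.43 log units; beyond the scatter).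

Compound 3 `COc1ccc(C(=O)/C=C/c2cc(-c3cc(OC)c(OC)c(OC)c3)n[nH]2)cc1` has not yet been measured in this assay. It differs from compound 2 in one place: 4-methoxyphenyl in place of 3,4-dichlorophenyl on a carbonyl carbon. Within the data shown here, the only step known for this position is the one from compound 1 to compound 2, which replaced a 4-aminophenyl with the 3,4-dichlorophenyl and was modest in size, as a 2.7-fold higher number from compound 1 to compound 2 (0.43 log units; beyond the scatter) shows. Among the measured compounds shown here, no step involving a 4-methoxyphenyl at this place has been measured, so the direction of the new step rests on that single comparison alone. Since moving away from the 3,4-dichlorophenyl reversed the earlier loss in the one case seen, a modest move to a lower number is expected for compound 3, by about a 2.0-fold lower number from compound 2 to compound 3 (0.29 log units; within the scatter). Compound 3 is therefore estimated at 1500 nM in this assay, within a range of 600 nM to 4000 nM.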

Compound 3, concentration for 50% growth inhibition: 1730 nM
Beside the measured number, compound 3's estimate is 1.2-fold (0.06 log units) below it, and the stated range covers the measured number.
By their numbers in this assay, from the lowest: compounds 1, 3 and 2 (each within the scatter of the next, the first and the last beyond it).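

In this assay, replacing the 3,4-dichlorophenyl on the carbonyl carbon with a 4-methoxyphenyl gives a 1.7-fold lower number from compound 2 to compound 3 (0.23 log units; within the scatter) and so cannot be told apart from the scatter of repeated measurements. Within the data shown here, the other new comparison, methoxy in place of amino on an aromatic carbon, gives a 1.6-fold higher number from compound 1 to compound 3 (0.20 log units; within the scatter) and is also within the scatter, so compound 3 cannot be separated from either neighbour, whereas the earlier compounds offered only a single step at this position, a 2.7-fold higher number from compound 1 to compound 2 (0.43 log units; beyond the scatter), which stays beyond the scatter and now appears as the combined span of two smaller, unresolved steps. Nothing available here explains why these three groups give such similar numbers.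

From the compounds shown here alone, what remains open is whether a carboxylic acid or an aliphatic amine on the aromatic ring attached to the carbonyl carbon, or a longer chain in place of that ring, would shift growth inhibition by more than the scatter. The compounds shown also cannot tell whether the small differences seen here would hold if the rest of the shared core were changed.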